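The source may hold more compounds than are shown below. What is called first, only, known or untested is meant among the compounds shown, and "the series" means these compounds.

Working notes on the series. Of the compounds shown here, two carry numbers so far. Compound 2, `O=C(Nc1cccc([N+](=O)[O-])c1)N1CCN(S(=O)(=O)c2sccc2-c2ccccc2Oc2ccc(O)c(O)c2)CC1`, gives 30% in an assay for binding affinity to Apoptosis regulator Bcl-2 (Homo sapiens), read by fluorescence polarization, with stated times of 30 min and 20 min, tested at 100 uM (on this read-out higher numbers stand for more inhibition at the one concentration tested (going by the name of the read-out) and lower numbers for less inhibition), the higher of the two results; the nearest is compound 1, `COc1ccc(Oc2ccccc2-c2ccsc2S(=O)(=O)N2CCN(C(=S)Nc3ccc([N+](=O)[O-])cc3)CC2)cc1OC`, which in this assay gives 16%, a gap beyond the usual scatter. Compound 1 differs from compound 2 in more than one place, so nothing can be read from that pair about any single change.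

Compound 3, `COc1ccc(Oc2ccccc2-c2ccsc2S(=O)(=O)N2CCN(C(=O)Nc3cccc([N+](=O)[O-])c3)CC2)cc1OC`, is not yet measured. It departs from compound 2 by 3,4-dimethoxyphenyl in place of 3,4-dihydroxyphenyl on an oxygen on an aromatic ring, and in no other way. For the measured compounds named here, no pair that differs only in this place has been measured, so the direction of the step is open. Compound 1 also carries the 3,4-dimethoxyphenyl and sits lower, but with its other differences it cannot settle the matter.

Expectation: a step of a number 10 percentage points lower from compound 2 to compound 3 (within the scatter) is estimated, a decrease of moderate size. Compound 3 is expected to give about 20% in this assay, with a range from 5% to 35%.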

Compound 3, a percentage reported as inhibition, at one concentration (the size of the read-out at that concentration, not a potency): 18%
Compound 3: the middle estimate sits 2 percentage points above what was measured; the range from low to high includes it.
By their numbers in this assay, from the lowest: compounds 1 and 3 (each within the scatter of the next); then compound 2.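

In this assay, the first pair differing only at this position gives a number 12 percentage points lower from compound 2 to compound 3 (beyond the scatter), so 3,4-dimethoxyphenyl in place of 3,4-dihydroxyphenyl on an oxygen on an aromatic ring now has a direction, though it rests on this single pair. With the 3,4-dimethoxyphenyl shared, the change on an amine nitrogen in a ring, from the sulfur-bearing group of compound 1 to the group of compound 3 with an added oxygen, gives a number 2 percentage points higher from compound 1 to compound 3 (within the scatter), so these two groups are not told apart here. Nothing measured on this series accounts for the step at the oxygen-linked aryl group.

Still open, on these data alone, is whether the step needs both hydroxyl groups to be replaced, which a phenyl carrying one hydroxyl and one methoxy would test, and whether a carboxylic acid on that ring would serve in the same way. For the compounds shown here, also open is whether the same step holds when the sulfur-bearing group of compound 1 sits on the amine nitrogen in a ring, since only one pair speaks to the change.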